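Removing the last methoxy from compound 2

The source may report more compounds than this note shows. Statements on the series, on what has been measured and on what is new or still open speak of the compounds shown alone.

Measured in a physicochemical assay, read by spectrophotometry, with a stated time of 30 min; on this read-out higher numbers stand for weaker inhibition and lower numbers for stronger inhibition:
- compound 1 `COc1cc(/C=N/NC(=O)CCCc2nc3ccccc3c(=O)[nH]2)cc(OC)c1O` gives 97000000 nM
- compound 2 `COc1cc(/C=N/NC(=O)CCCc2nc3ccccc3c(=O)[nH]2)cc(O)c1O` gives 88000000 nM
- compound 3 `O=C(CCc1nc2ccccc2c(=O)[nH]1)N/N=C/c1ccccc1` gives 734000000 nM

Compound 2 stands level with compound 1, since the two numbers lie within the scatter of each other. Compound 3 gives a clearly higher number than either, but it differs from them in its chain as well as on the aromatic ring, so its value cannot be tied to a single change.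

The next compound is compound 4 `O=C(CCCc1nc2ccccc2c(=O)[nH]1)N/N=C/c1ccc(O)c(O)c1`, which differs from compound 2 in one place, with hydrogen in place of methoxy on an aromatic carbon. This exact change has not been measured in the series. The closest evidence is a 1.1-fold lower number from compound 1 to compound 2 (0.04 log units; within the scatter), where hydrogen replaced methyl on an oxygen on an aromatic ring of the same part of the molecule. That step stayed within the scatter, though it leaves the ring carbon's oxygen in place, so it bears on the new change only in part.

On that basis, no step beyond the scatter is expected in this assay, in either direction. The expected change is a 1.1-fold higher number from compound 2 to compound 4 (0.06 log units; within the scatter). For compound 4 the estimated value is 100000000 nM, with an expected range from 45000000 nM to 220000000 nM.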

Compound 4, half-maximal inhibitory concentration: 95000000 nM
Compound 4: the middle estimate sits 1.1-fold (0.02 log units) above what was measured, within the range that was stated.
By their numbers in this assay, from the lowest: compounds 2, 4 and 1 (each within the scatter of the next); then compound 3.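

In this assay, replacing the methoxy on this aromatic carbon, ortho to a hydroxy group, with hydrogen gives a 1.1-fold higher number from compound 2 to compound 4 (0.03 log units; within the scatter), so the whole group, oxygen and methyl together, leaves without a step beyond the scatter. The earlier compounds had shown only a smaller change at the other methoxy of compound 1, where the oxygen stayed on the ring and hydrogen replaced the methyl, giving a 1.1-fold lower number from compound 1 to compound 2 (0.04 log units; within the scatter). The new step extends that picture to the loss of a complete methoxy, but no measurement shown offers any explanation for the lack of a clear shift at this position.

As far as these compounds go, it remains open whether a group other than hydrogen or methoxy at this carbon, such as an amine or a carboxylic acid, would move the number beyond the scatter. Compound 3, at 734000000 nM, differs from compound 4 both in its chain and on the aromatic ring, so the compounds shown do not separate those two changes, and they leave open what a longer chain would do.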